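Swapping a ring for a tert-butyl on the sulfonamide

The source may hold more compounds than are shown below. What is called first, only, known or untested is meant among the compounds shown, and "the series" means these compounds.

Three compounds share one core and differ only in the group on the sulfonyl sulfur. Compound 1, `Cc1ccc(S(=O)(=O)N(C)C(C)C)cc1C#Cc1cc(Cl)ccc1OCC(=O)O`, gives in an assay on CHO cells for displacement of a labelled ligand from prostaglandin D2 receptor 2 (Homo sapiens), read by scintillation counting (on this read-out lower numbers stand for stronger inhibition and higher numbers for weaker inhibition), a value of 3.8 nM. Compound 2, `Cc1ccc(S(=O)(=O)N(C)CCCN(C)C)cc1C#Cc1cc(Cl)ccc1OCC(=O)O`, gives 287 nM in this assay, and compound 3, `Cc1ccc(S(=O)(=O)N2CCCCC2C)cc1C#Cc1cc(Cl)ccc1OCC(=O)O`, gives 1.9 nM. Compound 3 holds the lowest of the three numbers, yet its gap to compound 1, a 2.0-fold lower number from compound 1 to compound 3 (0.30 log units; within the scatter), is within the scatter, so the two cannot be ranked; compound 2 stands far away, a 150-fold lower number from compound 2 to compound 3 (2.18 log units; beyond the scatter). Compound 4, `Cc1ccc(S(=O)(=O)NC(C)(C)C)cc1C#Cc1cc(Cl)ccc1OCC(=O)O`, carries the change ((tert-butyl)amino in place of 2-methylpiperidin-1-yl on a sulfonyl sulfur). Among the measured compounds shown here, two measured steps bear on it: a 2.0-fold lower number from compound 1 to compound 3 (0.30 log units; within the scatter) shows that exchanging one compact alkyl group for another hardly moves the number, while a 76-fold higher number from compound 1 to compound 2 (1.88 log units; beyond the scatter) shows that the 3-(dimethylamino)propyl chain raises it greatly. For the measured compounds named here, no measured compound carries a hydrogen-bond donor on this nitrogen. The tert-butyl group resembles the isopropyl of compound 1 more than the chain of compound 2. A small step, a 3.2-fold higher number from compound 3 to compound 4 (0.50 log units; beyond the scatter), is expected, within or near the scatter. Compound 4 is therefore estimated at 6 nM, with a range from 1.5 nM to 25 nM.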

Compound 4, inhibition constant: 5 nM
Estimate against measurement, compound 4: 1.2-fold (0.08 log units) above; the measured number falls inside the stated range.
By their numbers in this assay, from the lowest: compounds 3, 1 and 4 (each within the scatter of the next, the first and the last beyond it); then compound 2.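

Among the compounds shown here, compound 4 is the first compound here with a hydrogen-bond donor on the sulfonamide nitrogen, and it has no ring in this group, yet a 1.3-fold higher number from compound 1 to compound 4 (0.12 log units; within the scatter) leaves it indistinguishable from compound 1. The donor is therefore compatible with a low number at this position. The change from the ring costs a little, a 2.6-fold higher number from compound 3 to compound 4 (0.42 log units; beyond the scatter), while a 57-fold lower number from compound 2 to compound 4 (1.76 log units; beyond the scatter) confirms that compound 2 stays far from the compact groups. No evidence is available on what lies behind these differences.

Compound 3 and compound 4 differ in both the ring and the nitrogen hydrogen, so the modest step cannot be assigned to either alone. A (tert-butyl)(methyl)amino group would separate these two changes, and an unsubstituted amino group would show whether the bulky alkyl group is needed at all.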